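Chain shortening across two cores: a working note

A few compounds are considered here, and "the series" means these few. Any claim that something is new, unique, unknown or untested is made for them only; others in the source may bear on it.

Compound 1 `CCCCCCCCc1cn([C@H]2C[C@@H]3OP(=O)(O)OC[C@H]3O2)c(=O)[nH]c1=O` gives 164 ug/mL in a functional assay on L1210 cells (Mus musculus); a higher number here means a weaker inhibitor, a lower number a stronger inhibitor. Compound 2 `CCCCCCc1cn([C@H]2C[C@@H]3OP(=O)(O)OC[C@H]3O2)c(=O)[nH]c1=O` carries the same core with the difference (hydrogen in place of ethyl on a saturated chain carbon, six bonds along the chain from an aromatic carbon). In this assay compound 2 gives only a limit, > 500 ug/mL. The step is therefore read as an at least 3.0-fold higher number from compound 1 to compound 2 (0.48 log units; beyond the scatter); its size rests on the limit of > 500 ug/mL in this assay, at which 1 of the 3 values shown sits, and is known only as a lower bound. Compound 3 `CCCCCc1cn([C@H]2C[C@H](O)[C@@H](CO)O2)c(=O)[nH]c1=O` sits on a different core; the difference between the two cores is not broken down here. In this assay compound 3 gives 476 ug/mL, a number beyond the scatter above that of compound 1. Compound 4 `CCCc1cn([C@H]2C[C@H](O)[C@@H](CO)O2)c(=O)[nH]c1=O` differs from compound 3 by hydrogen in place of ethyl on a saturated chain carbon, three bonds along the chain from an aromatic carbon. The place differs from the earlier pair, three bonds along the chain rather than six, so this is the same kind of change, not the same change. Compound 4 is expected to give 1200 ug/mL because the same kind of change gave an at least 3.0-fold higher number from compound 1 to compound 2 (0.48 log units; beyond the scatter). The expected step is a 2.5-fold higher number from compound 3 to compound 4 (0.40 log units; beyond the scatter), most likely ending at the same limit, between 500 ug/mL and 3000 ug/mL.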

Compound 4, concentration for 50% inhibition: > 500 ug/mL
Compound 4: only a limit was reported (the forecaster's own chance of this, stated with the estimate: 75%); the middle value does not contradict the limit.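

In this assay compound 4 gives only a limit, > 500 ug/mL. The new step therefore reads as an at least 1.0-fold higher number from compound 3 to compound 4 (0.02 log units; that floor lies within the scatter), a floor and not a measured size, so hydrogen in place of ethyl on the core of compound 3 has no demonstrated effect beyond the scatter, though a larger one is not excluded. The two steps are the same kind of change at different places along the chain, and the data do not show whether its size carries from one core to the other: the same change on two cores in this assay, an at least 3.0-fold higher number (0.48 log units; beyond the scatter) from compound 1 to compound 2 and an at least 1.0-fold higher number (0.02 log units; that floor lies within the scatter) from compound 3 to compound 4; the limit leaves it open whether they differ. The direction seen on the core of compound 1 is thus neither confirmed nor contradicted on the core of compound 3, and both shortened compounds give only a limit: the limit of > 500 ug/mL in this assay, at which 2 of the 4 values shown sit.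

Open, from the compounds shown here alone, is how a chain longer than pentyl would read on the core of compound 3, where a pair of values clear of the limit would allow a direct comparison of steps. Also open, going by these compounds, is how an amine or a carboxylic acid in place of the chain would read in this assay.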